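The compounds below may be only part of what the source reports. "The series", "measured", "known", "first", "only" and "open" are said of these compounds alone.

Measured so far:
Compound 1, `C[C@@H](NC(=O)Nc1ccccc1Br)c1ccccc1`, in an ADME assay on the whole organism with Oryza sativa as the target, tested at 10 uM (on this read-out lower numbers stand for a stronger effect and higher numbers for a weaker effect at the one concentration tested), compound 1 gives 94%.
Compound 2, `C[C@@H](NC(=O)Nc1cccc(Br)c1)c1ccccc1`, in this assay compound 2 gives 99%.
Compound 3, `C[C@@H](NC(=O)Nc1ccccc1I)c1ccccc1`, in this assay compound 3 gives 96%.

The three measured compounds share one urea scaffold and differ only in the halogen on the anilide ring and in where it sits. Compound 1 and compound 3 are linked by one change, (iodo in place of bromo on an aromatic carbon), and the step is a number 2 percentage points higher from compound 1 to compound 3 (within the scatter). Compound 2 has the highest of the three numbers, but its gaps to compound 3 and to compound 1 both lie within the scatter, so the three values cannot be told apart. Compound 1 and compound 2 have the same atoms joined differently; the difference between the two cores is not broken down here.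

Compound 4, `C[C@@H](NC(=O)Nc1cccc(I)c1)c1ccccc1`, is not yet measured. It stands to compound 2 as compound 3 stands to compound 1: iodo in place of bromo on an aromatic carbon. The surroundings are not the same word for word, since in the earlier pair the halogen sits ortho to a large group and here it sits meta to a large group, so this is the same kind of change rather than the same change. The step from compound 2 to compound 4 is expected to be no change at the digits printed from compound 2 to compound 4 (within the scatter), beside the earlier one, because a number 2 percentage points higher from compound 1 to compound 3 (within the scatter) was within the scatter and compound 2 already sits near the top of the range. Compound 4 is therefore estimated at 99%, with a likely range from 91% to 104%.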

Compound 4, a percentage reported as activity, at one concentration (the size of the read-out at that concentration, not a potency): 73%
Beside the measured number, compound 4's estimate is 26 percentage points above it, outside the stated range (below it).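

In this assay, iodo in place of bromo on an aromatic carbon, here meta to a large group, gives a number 26 percentage points lower from compound 2 to compound 4 (beyond the scatter), so in this pair the exchange of one halogen for the other is accompanied by a real shift in the read-out. Set beside the earlier pair, the same exchange does not carry over unchanged from one core to the other, and a result seen on one core cannot be taken as a guide to the result on the other: the same change on two cores in this assay, a number 2 percentage points higher (within the scatter) from compound 1 to compound 3 and a number 26 percentage points lower (beyond the scatter) from compound 2 to compound 4, 28 percentage points apart, beyond the scatter of two such steps. Among the compounds shown here, this rests on only two pairs, so it does not show whether the gap goes with where the halogen sits or with something else that separates the two cores, and it offers no rule for any further core.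

The compounds shown leave open whether the shift belongs to iodo alone or would also appear with chloro, methyl or trifluoromethyl in the same place, meta to a large group. They also leave open how an amine or a carboxylic acid on the shared core would behave in this assay, and whether such groups would respond to the halogen exchange in the same way.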